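A few compounds are considered here, and "the series" means these few. Any claim that something is new, unique, unknown or untested is made for them only; others in the source may bear on it.

Series so far:
compound 1 `O=c1cc(/C=N\c2ccc(O)cc2)c2ccc(OCc3ccccc3)cc2o1` gives 64500 nM in a functional assay, read by spectrophotometry, with a stated time of 3 min; on this read-out higher numbers stand for weaker inhibition and lower numbers for stronger inhibition
compound 2 `N/N=C\c1cc(=O)oc2cc(OCc3ccccc3)cc(OCc3ccccc3)c12` gives 363000 nM
compound 3 `N/N=C\c1cc(=O)oc2cc(OCc3ccccc3)ccc12` gives 9740 nM

Compound 2 stands highest of the three numbers in this assay; compound 1 lies nearest and compound 3 furthest, the step of a 37-fold lower number from compound 2 to compound 3 (1.57 log units; beyond the scatter) being large. Compound 4 `O=c1cc(/C=N\Nc2ccccc2)c2c(OCc3ccccc3)cc(OCc3ccccc3)cc2o1` differs from compound 2 by phenyl in place of hydrogen on an amine nitrogen, the same difference cut one bond further out reading amino to anilino. The step that bears on this is a 6.6-fold lower number from compound 1 to compound 3 (0.82 log units; beyond the scatter), in which a 4-hydroxyphenyl on the double-bonded nitrogen went with a higher number than amino. By that analogy an aryl on this nitrogen is expected to leave the number unchanged or somewhat higher. The expected step is a 1.4-fold higher number from compound 2 to compound 4 (0.14 log units; within the scatter). Compound 4 is therefore estimated at 500000 nM, within 120000 nM to 2000000 nM.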

Compound 4, half-maximal inhibitory concentration: 40100 nM
Estimate against measurement, compound 4: 12-fold (1.10 log units) above; measured number below the stated range.
By their numbers in this assay, from the lowest: compound 3; then compounds 4 and 1 (each within the scatter of the next); then compound 2.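

In this assay, phenyl in place of hydrogen on the amine nitrogen gives a 9.1-fold lower number from compound 2 to compound 4 (0.96 log units; beyond the scatter), so a six-membered aromatic ring here goes with stronger inhibition. This runs opposite to a 6.6-fold lower number from compound 1 to compound 3 (0.82 log units; beyond the scatter), where the aryl-bearing compound had the higher number, so that earlier step does not carry over to this nitrogen on the core of compound 2. No measurement at hand accounts for the opposite direction. Open, going by these compounds, is whether phenyl gives a similar step on the core of compound 3. Also open, on these data alone, is how a methyl, a longer alkyl chain or a carboxylic acid on this nitrogen would compare.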